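Antiproliferative series on the coumarin amide core: step to compound 3

The source may hold more compounds than are shown below. What is called first, only, known or untested is meant among the compounds shown, and "the series" means these compounds.

Measured compounds:
compound 1 `CC(=O)Oc1ccc(C(=O)Nc2cc3ccc(OCC4CCN(C)C4)c(C)c3oc2=O)cc1CC=C(C)C` — 1880 nM
compound 2 `CC(C)=CCc1cc(C(=O)Nc2cc3ccc(OCCCN(C)C(C)C)c(C)c3oc2=O)ccc1O` — 1050 nM

Two compounds have been run in a functional assay on MCF7 cells (Homo sapiens) for antiproliferative activity; a higher number here means a weaker inhibitor, a lower number a stronger inhibitor. Compound 1 gives 1880 nM and compound 2 gives 1050 nM. Among the compounds with values here, compound 2 has the lowest of the two numbers; the gap to compound 1 lies within the scatter, so the two are not separable on these data, and no step between compounds differing in one place is available.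

Compound 3 `CC(C)=CCc1cc(C(=O)Nc2cc3ccc(OCCCN[C@H](C)c4ccccc4)c(C)c3oc2=O)ccc1O` is not yet measured. Its difference from compound 2: (1-phenylethyl)amino in place of isopropyl(methyl)amino on a saturated chain carbon, three bonds along the chain from an oxygen on an aromatic ring. Both compounds keep the shared core and the chain linking it to the amine; only the substituents on the nitrogen change, in the place named above.

With no measured step of this kind in the set, the size of the effect in this assay is uncertain. The expectation is a modest step toward a lower number, of the order of a 1.5-fold lower number from compound 2 to compound 3 (0.18 log units; within the scatter), though a result within the scatter of compound 2 would not be surprising. Compound 3 is accordingly estimated at 700 nM, with a plausible range from 250 nM to 2500 nM.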

Compound 3, half-maximal inhibitory concentration: 1450 nM
For compound 3 the middle estimate is 2.1-fold (0.32 log units) below the measured one, and the stated range covers the measured number.
By their numbers in this assay, from the lowest: compounds 2, 3 and 1 (each within the scatter of the next).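

In this assay, within the data shown here, putting (1-phenylethyl)amino in place of isopropyl(methyl)amino on a saturated chain carbon, three bonds along the chain from an oxygen on an aromatic ring, gives a 1.4-fold higher number from compound 2 to compound 3 (0.14 log units; within the scatter) and provides the first step in this set that differs in one place. The entering group adds a six-membered aromatic ring of carbon only, a hydrogen-bond donor and a defined stereocentre, yet compound 2 and compound 3 cannot be separated on this read-out, so this position accepts that much larger amine substituent without a step beyond the scatter. Nothing on hand explains this outcome.

A single step cannot separate the contributions of the ring, the stereocentre and the amine hydrogen; the opposite enantiomer of the (1-phenylethyl)amino group, a plain benzylamino group and an N-methyl-N-(1-phenylethyl)amino group would address these in turn. From the compounds shown here alone, it also remains open whether a ring amine such as piperidine or morpholino, or a shorter or longer chain, would produce a step beyond the scatter at this position.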